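The source may report more compounds than this note shows. Statements on the series, on what has been measured and on what is new or still open speak of the compounds shown alone.

Working notes on the series. Within the data shown here, compound 1 `O=C(N1CCCN(Cc2ccc(OCc3ccccc3)cc2)CC1)n1cccn1` in an assay on membranes from brain for binding affinity to Monoacylglycerol lipase ABHD6 (Mus musculus), read by fluorescence, with stated times of 1 h and 30 min (on this read-out higher numbers stand for weaker inhibition and lower numbers for stronger inhibition), gives 960 nM, the only measured number in the set. Compound 2 `Cc1cnn(C(=O)N2CCN(C(c3ccc4ccccc4c3)c3ccc4ccccc4c3)CC2)c1` is a different case: in this assay compound 2 gives only the limit > 100000 nM, not a number. Of the two values shown, one sits at that limit (the limit of > 100000 nM in this assay, at which 1 of the 2 values shown sits), so compound 2 stands at the weak end of what is shown. Among the measured compounds shown here, compound 1 and compound 2 differ in more than one place, and no step between measured compounds is available from them.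

Compound 3 `O=C(N1CCN(C(c2ccc3ccccc3c2)c2ccc3ccccc3c2)CC1)n1cccn1`, not yet measured, differs from compound 2 by hydrogen in place of methyl on an aromatic carbon. Such a small change is expected to give no step beyond the usual scatter, so the expected step from compound 2 to compound 3 in this assay is a step that the limit leaves unreadable from compound 2 to compound 3. Compound 3 is accordingly estimated at 150000 nM in this assay, within 30000 nM to 1000000 nM, with a real chance that this assay again returns only a limit.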

Compound 3, half-maximal inhibitory concentration: > 100000 nM
Compound 3 was reported as a limit; the forecaster's own chance of this, stated with the estimate: 75%; the middle value does not contradict the limit.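

In this assay, compound 2 and compound 3 are both reported only as limits, so no step between them can be read: the limit of > 100000 nM in this assay, at which 2 of the 3 values shown sit.

The compounds shown leave open whether going from 4-methyl-1H-pyrazol-1-yl to 1H-pyrazol-1-yl changes inhibition at all on the shared core.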